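Hexyl in place of an aromatic ring on the hydrazide

The source may report more compounds than this note shows. Statements on the series, on what has been measured and on what is new or still open speak of the compounds shown alone.

Compound 3 `Cc1ccc(C(=O)NN(C(=O)c2ccccc2Cl)C(C)(C)C)cc1C` carries the highest number of the three measured compounds in an assay on cells for agonist activity at ecdysone receptor (Bombyx mori), read by a luciferase reporter, with a stated time of 24 h; a higher number here means that more compound is needed for the effect, a lower number that less compound is needed: compound 3 gives 87.1 nM, compound 1 `CC(C)(C)N(NC(=O)c1ccc(Br)cc1)C(=O)c1ccccc1Cl` gives 33.9 nM, and compound 2 `Cc1cccc(C(=O)NN(C(=O)c2ccccc2Cl)C(C)(C)C)c1C` gives 20 nM. The steps among them, a 1.7-fold lower number from compound 1 to compound 2 (0.23 log units; within the scatter), a 2.6-fold higher number from compound 1 to compound 3 (0.41 log units; beyond the scatter) and a 4.4-fold higher number from compound 2 to compound 3 (0.64 log units; beyond the scatter), all swap one substituted phenyl for another on the same carbonyl carbon, and none moves the number by more than a modest amount.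

Compound 4 `CCCCCCC(=O)NN(C(=O)c1ccccc1Cl)C(C)(C)C` differs from compound 3 by hexyl in place of 3,4-dimethylphenyl on a carbonyl carbon. Within the data shown here, no measured step removes the aromatic ring altogether, so the measured steps bear on it only loosely: they show that the number is sensitive to the pattern on that ring, while saying nothing about a chain in its place. Because the three aryl variants span only the range from compound 2 at 20 nM to compound 3 at 87.1 nM, the effect of losing the ring entirely is uncertain, and a larger increase in the number is expected. Compound 4 is therefore estimated at 1200 nM, with a range from 150 nM to 10000 nM, meaning an expected step of a 14-fold higher number from compound 3 to compound 4 (1.14 log units; beyond the scatter) in this assay.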

Compound 4, half-maximal effective concentration: 741 nM
Beside the measured number, compound 4's estimate is 1.6-fold (0.21 log units) above it, and the stated range covers the measured number.
By their numbers in this assay, from the lowest: compounds 2 and 1 (each within the scatter of the next); then compound 3; then compound 4.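

In this assay hexyl on this carbonyl carbon moves the number further than any swap of one substituted phenyl for another (an 8.5-fold higher number from compound 3 to compound 4 (0.93 log units; beyond the scatter)). Against the other two aryl compounds the same change is large (a 22-fold higher number from compound 1 to compound 4 (1.34 log units; beyond the scatter); a 37-fold higher number from compound 2 to compound 4 (1.57 log units; beyond the scatter)), so in all three pairs the aromatic ring goes with the lower number, although compound 4 still gives a measurable half-maximal effective concentration. No measurement shown here explains this difference.

The compounds shown leave open whether the loss follows from the absence of a ring as such or from this particular chain. A cyclohexyl group, which keeps a ring without aromatic character, or a shorter butyl or longer octyl chain at the same place would separate these readings.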